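Urea aryl exchange on a shared core: compound 4 awaited

The compounds below may be only part of what the source reports. "The series", "measured", "known", "first", "only" and "open" are said of these compounds alone.

Three compounds have been measured in a functional assay on MKN-45 cells (Homo sapiens) for cytotoxicity, read by MTT assay, with a stated time of 72 h; on this read-out higher numbers stand for weaker inhibition and lower numbers for stronger inhibition:
compound 1, `CN(C)CCCNc1nc(-c2ccc(NC(=O)Nc3ccc(Cl)cc3)cc2)nc2c(Cl)c(Cl)sc12`, gives 1530 nM
compound 2, `CN(C)CCCNc1nc(-c2ccc(NC(=O)Nc3ccccc3Cl)cc2)nc2c(Cl)c(Cl)sc12`, gives 1330 nM
compound 3, `CN(C)CCCNc1nc(-c2ccc(NC(=O)Nc3ccc(Cl)cc3Cl)cc2)nc2c(Cl)c(Cl)sc12`, gives 2560 nM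

Compound 3 carries the highest number of the three, yet its gaps to compound 1 and to compound 2 both sit within the scatter, so no ordering among them can be drawn. Compound 4, `Cc1ccc(NC(=O)Nc2ccc(-c3nc(NCCCN(C)C)c4sc(Cl)c(Cl)c4n3)cc2)cc1`, differs from compound 3 by 4-methylphenyl in place of 2,4-dichlorophenyl on an amide-type nitrogen. Within the data shown here, no measured step exchanges a chloro for a methyl. The steps that touch the same aryl ring are a 1.2-fold lower number from compound 1 to compound 2 (0.06 log units; within the scatter), a 1.7-fold higher number from compound 1 to compound 3 (0.22 log units; within the scatter) and a 1.9-fold higher number from compound 2 to compound 3 (0.28 log units; within the scatter), each of them within the scatter. On that basis the change to compound 4 is expected to move the number in this assay little, at most modestly downward, which is a 1.4-fold lower number from compound 3 to compound 4 (0.15 log units; within the scatter). For compound 4 the expected value is 1800 nM, with a range from 700 nM to 4500 nM.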

Compound 4, half-maximal inhibitory concentration: 3700 nM
The estimate for compound 4 lay 2.1-fold (0.31 log units) below the measured number; measured number inside the range.
By their numbers in this assay, from the lowest: compounds 2, 1, 3 and 4 (each within the scatter of the next, the first and the last beyond it).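

In this assay, among these compounds, the exchanges on this aryl ring had so far stayed within the scatter, and 4-methylphenyl on the amide-type nitrogen now gives the first steps beyond it: a 2.8-fold higher number from compound 2 to compound 4 (0.44 log units; beyond the scatter) and a 2.4-fold higher number from compound 1 to compound 4 (0.38 log units; beyond the scatter) are both modest. Among the compounds shown here, the second of these is the only exchange of chloro for methyl on an aromatic carbon, and it shows that this single change can be told apart, though only just. Against 2,4-dichlorophenyl the picture differs, since a 1.4-fold higher number from compound 3 to compound 4 (0.16 log units; within the scatter) stays within the scatter, and nothing at hand accounts for these steps.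

As far as these compounds go, whether a methoxy or a trifluoromethyl group on this ring would follow methyl or chloro remains open. So does what an unsubstituted phenyl would give on this nitrogen.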